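The source may report more compounds than this note shows. Statements on the series, on what has been measured and on what is new or still open speak of the compounds shown alone.

Measured in a functional assay on HT-29 cells (Homo sapiens) for inhibition, read by sulforhodamine B assay, with a stated time of 48 h; on this read-out lower numbers stand for stronger inhibition of growth and higher numbers for weaker inhibition of growth:

compound 1 `COc1ccc(C(=O)NNC(=O)c2ccc3[nH]c(-c4ccc([N+](=O)[O-])o4)nc3c2)cc1OC`: 15.6 ug/mL
compound 2 `COc1cc(C(=O)NNC(=O)c2ccc3[nH]c(-c4ccc([N+](=O)[O-])o4)nc3c2)cc(OC)c1OC`: 31.3 ug/mL
compound 3 `O=C(NNC(=O)c1ccc2[nH]c(-c3ccc([N+](=O)[O-])o3)nc2c1)c1cccc(Oc2ccccc2)c1`: > 7.8 ug/mL

Within the data shown here, compound 1 sits at the lowest of the two numbers in this assay; the only other number, that of compound 2, lies within the scatter of it, so the two compounds are not separated. For compound 3 the assay reports a limit rather than a number, (the limit of > 7.8 ug/mL in this assay, at which 1 of the 3 values shown sits).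

Among the measured compounds shown here, the one measured step on the shared core, a 2.0-fold higher number from compound 1 to compound 2 (0.30 log units; within the scatter), concerns a methoxy added to the 3,4-dimethoxyphenyl group and does not pass beyond the scatter.

Compound 4 `O=C(NNC(=O)c1ccc2[nH]c(-c3ccc([N+](=O)[O-])o3)nc2c1)c1ccccc1` has not been measured in this assay. It differs from compound 1 as phenyl in place of 3,4-dimethoxyphenyl on a carbonyl carbon. For the measured compounds named here, no measured step removes both methoxy groups from the same carbonyl-bound ring, so the step from compound 1 to compound 4 has no direct precedent; the only measured change on that ring, the step to compound 2, stayed within the scatter. On that basis a step of little size is expected, a 1.3-fold higher number from compound 1 to compound 4 (0.11 log units; within the scatter), with the limit seen for compound 3 kept in mind as a possible outcome. Compound 4 is estimated at 20 ug/mL in this assay, in the range 8 ug/mL to 50 ug/mL.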

Compound 4, concentration for 50% growth inhibition: 31.3 ug/mL
Beside the measured number, compound 4's estimate is 1.6-fold (0.19 log units) below it, within the range that was stated.
By their numbers in this assay, from the lowest: compounds 1, 2 and 4 (each within the scatter of the next).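

Replacing the 3,4-dimethoxyphenyl with phenyl on a carbonyl carbon gives, in this assay, a 2.0-fold higher number from compound 1 to compound 4 (0.30 log units; within the scatter). The earlier step only added a methoxy to this ring, whereas this one removes both methoxy groups, and that larger change also stays within the scatter, so these compounds do not show that the methoxy groups on this ring are needed for the growth inhibition read here. The step from compound 3 to compound 4 cannot be read, because compound 3 carries a limit and not a number: the limit of > 7.8 ug/mL in this assay, at which 1 of the 4 values shown sits.

As far as these compounds go, whether any change at this position can pass beyond the scatter remains open, for instance a phenyl ring carrying an amine or a carboxylic acid, or a longer chain in place of the ring. All the compounds shown keep the shared core with its nitro group, so the effect of a change there, such as an amine in place of the nitro group, also remains open.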